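This account rests on a few compounds, and the source may have more. Where it says the series, first, only, none or still open, it means among the compounds named here.

The measured compounds, all assessed in an assay on isolated protein (Bos taurus) with 5-hydroxytryptamine receptor 1D (Homo sapiens) as the target; on this read-out higher numbers stand for weaker inhibition and lower numbers for stronger inhibition:

Compound 1 `c1cnc(NCCCNCC2CCc3ccccc3O2)nc1`: 1.59 nM
Compound 2 `c1ccc2c(c1)CCC(CNCCCNC1=NCCN1)O2`: 6.31 nM
Compound 3 `CC(C)/N=C(\N)NNCCCNCC1CCc2ccccc2O1`: 3.16 nM

Compound 3 sits close to both of its neighbours in this assay: the step of a 2.0-fold higher number from compound 1 to compound 3 (0.30 log units; within the scatter) and the step of a 2.0-fold lower number from compound 2 to compound 3 (0.30 log units; within the scatter) are each within the scatter, so the three numbers cannot be ranked with confidence against one another. Among the compounds with values here, the only change that clearly registered is the step of a 4.0-fold higher number from compound 1 to compound 2 (0.60 log units; beyond the scatter), which is modest.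

Compound 4 `O=C1CCCN=C(NCCCNCC2CCc3ccccc3O2)N1` is the next compound. Its change against compound 3 is a group of 8 heavy atoms (5 carbon, 2 nitrogen, 1 oxygen; one seven-membered non-aromatic ring with 2 hetero atoms) in place of a group of 7 heavy atoms (4 carbon, 3 nitrogen; no ring), on an amine nitrogen. Within the data shown here, every measured step so far has altered exactly this position, the group attached to the amine nitrogen whose other neighbour is a saturated chain carbon, and the three groups tried there gave numbers spanning only a modest interval. Compound 4 introduces a seven-membered non-aromatic ring with two hetero atoms and a second acceptor at that position; nothing measured here speaks directly to that ring. The expected outcome for compound 4 is therefore a step of a 1.3-fold higher number from compound 3 to compound 4 (0.10 log units; within the scatter) in this assay, most likely within the scatter, since every swap at this position has stayed small. Compound 4 is estimated at 4 nM, with a range from 1.5 nM to 12 nM.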

Compound 4, half-maximal inhibitory concentration: 158 nM
Compound 4: middle estimate off by 40-fold (1.60 log units), on the low side; the whole stated range lies below it.
By their numbers in this assay, from the lowest: compounds 1, 3 and 2 (each within the scatter of the next, the first and the last beyond it); then compound 4.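

Within the data shown here, the result shows that this position is far less forgiving than the earlier compounds suggested: in this assay, the group bearing a seven-membered non-aromatic ring with 2 hetero atoms gives much larger steps (a 50-fold higher number from compound 3 to compound 4 (1.70 log units; beyond the scatter); a 25-fold higher number from compound 2 to compound 4 (1.40 log units; beyond the scatter); a 99-fold higher number from compound 1 to compound 4 (2.00 log units; beyond the scatter)) than the largest step among the earlier compounds (a 4.0-fold higher number from compound 1 to compound 2 (0.60 log units; beyond the scatter)). A ring on the amine nitrogen does not by itself go with such a rise, since compound 1 and compound 2 both carry one and remain in the low group of numbers, while the open-chain group of compound 3 sits among them. No measurement shown here accounts for the rise seen with compound 4.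

The group in compound 4 differs from the others in both its ring size and its carbonyl oxygen, so the compounds shown cannot assign the rise to either feature. On these data alone, a seven-membered ring without the carbonyl, or a five- or six-membered non-aromatic ring carrying a carbonyl, would separate the two, and how far the rise extends to other groups on this amine nitrogen also remains open.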